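The compounds below may be only part of what the source reports. "The series", "measured", "known", "first", "only" and "open" are said of these compounds alone.

Compound 1 `COc1ccc(/C=C/c2nc(NCCN(C(C)C)C(C)C)c3cc(Cl)ccc3n2)cc1OC` and compound 2 `COc1ccc(/C=C/c2nc(NCCN3CCCCC3)c3cc(Cl)ccc3n2)cc1OC` share one core and differ only in the amine at the end of the side chain. In a functional assay on PC-3 cells (Homo sapiens) for cytotoxicity, read by MTT assay, with stated times of 48 h and 4 h (a lower number here means a stronger inhibitor, a higher number a weaker inhibitor), compound 1 gives only a limit, > 100000 nM. In this assay compound 2 gives 21200 nM. The change piperidin-1-yl in place of diisopropylamino on a saturated chain carbon, two bonds along the chain from a nitrogen on an aromatic ring thus brings an at least 4.7-fold lower number from compound 1 to compound 2 (0.67 log units; beyond the scatter). Compound 3 `CC(C)N(CCNc1nc(/C=C/c2ccc([N+](=O)[O-])cc2)nc2ccccc12)C(C)C` carries a different core; the difference between the two cores is not broken down here. In this assay compound 3 gives only a limit, > 100000 nM. Because of the limit of > 100000 nM in this assay, at which 2 of the 3 values shown sit, the measured step can only be read as a lower bound. Compound 4 `O=[N+]([O-])c1ccc(/C=C/c2nc(NCCN3CCCCC3)c3ccccc3n2)cc1` is not yet measured; it differs from compound 3 by piperidin-1-yl in place of diisopropylamino on a saturated chain carbon, two bonds along the chain from a nitrogen on an aromatic ring, the same change seen between compound 1 and compound 2. He expects a step of an at least 2.5-fold lower number from compound 3 to compound 4 (0.39 log units; beyond the scatter) in this assay, resting on the step from compound 1 to compound 2, an at least 4.7-fold lower number from compound 1 to compound 2 (0.67 log units; beyond the scatter), while noting that compound 3 sits at the limit > 100000 nM. For compound 4 he estimates 40000 nM in this assay, within 10000 nM to 150000 nM.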

Compound 4, half-maximal inhibitory concentration: 25600 nM
The estimate for compound 4 lay 1.6-fold (0.19 log units) above the measured number; low and high end bracket the measured number.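

In this assay the change to piperidin-1-yl in place of diisopropylamino also lowered the number on the second core, with an at least 3.9-fold lower number from compound 3 to compound 4 (0.59 log units; beyond the scatter). Set beside the earlier case, the change points the same way on both cores, which is as much as two cores can show: the same change on two cores in this assay, an at least 4.7-fold lower number (0.67 log units; beyond the scatter) from compound 1 to compound 2 and an at least 3.9-fold lower number (0.59 log units; beyond the scatter) from compound 3 to compound 4; the limit leaves it open whether they differ. Neither step has a true size, so the data give a direction and a lower bound but do not show whether the core alters how much the change matters, because each step starts from a limit of the assay and not from a number: the limit of > 100000 nM in this assay, at which 2 of the 4 values shown sit.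

The compounds shown leave open whether the same holds for other amines on the chain, such as morpholine or dimethylamine, or for a longer chain carrying the piperidin-1-yl. They also leave open what the chlorine, the methoxy groups and the nitro group each contribute, as compound 2 and compound 4 differ in more than one place.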